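A few compounds are considered here, and "the series" means these few. Any claim that something is new, unique, unknown or untested is made for them only; others in the source may bear on it.

Three compounds share one core and differ only in the group attached to a nitrogen on an aromatic ring. Compound 1 `NS(=O)(=O)c1ccc(NC(=S)Nc2ccc3ncnc(Nc4ccc(F)c(Br)c4)c3c2)cc1` gives 18200 nM in a functional assay on A-431 cells (Homo sapiens) for antiproliferative activity, read by MTT assay, with a stated time of 72 h; a lower number here means a stronger inhibitor, a higher number a weaker inhibitor. Compound 2 `NS(=O)(=O)c1ccc(NC(=S)Nc2ccc3ncnc(Nc4ccc(C(F)(F)F)cc4)c3c2)cc1` gives 18000 nM in this assay, and compound 3 `NS(=O)(=O)c1ccc(NC(=S)Nc2ccc3ncnc(Nc4cccc(F)c4)c3c2)cc1` gives 30100 nM. The three numbers sit close together: a 1.0-fold lower number from compound 1 to compound 2 (0.00 log units; within the scatter), a 1.7-fold higher number from compound 1 to compound 3 (0.22 log units; within the scatter), and a 1.7-fold higher number from compound 2 to compound 3 (0.22 log units; within the scatter), so compound 3 stands at the top end of a group whose members cannot be told apart with confidence.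

Compound 4 `CCc1ccc(Nc2ncnc3ccc(NC(=S)Nc4ccc(S(N)(=O)=O)cc4)cc23)cc1` carries the change (4-ethylphenyl in place of 3-fluorophenyl on a nitrogen on an aromatic ring). Every step measured so far swaps one such aromatic group for another, and none moved the number beyond the scatter, so the bearing of those steps is that this swap is also expected to leave the number essentially where it is, with no direction favoured.

Compound 4 is therefore estimated at 24000 nM in this assay, within a range of 8000 nM to 70000 nM, meaning an expected step of a 1.3-fold lower number from compound 3 to compound 4 (0.10 log units; within the scatter).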

Compound 4, half-maximal inhibitory concentration: 38400 nM
Beside the measured number, compound 4's estimate is 1.6-fold (0.20 log units) below it; measured number inside the range.
By their numbers in this assay, from the lowest: compounds 2, 1, 3 and 4 (each within the scatter of the next, the first and the last beyond it).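

In this assay, this position now gives its first steps beyond the scatter, both modest: (a 2.1-fold higher number from compound 2 to compound 4 (0.33 log units; beyond the scatter)) and (a 2.1-fold higher number from compound 1 to compound 4 (0.32 log units; beyond the scatter)). The first of these is a single change, ethyl in place of trifluoromethyl on an aromatic carbon, so the group on this ring can shift the number slightly, even though the step from the 3-fluorophenyl compound (a 1.3-fold higher number from compound 3 to compound 4 (0.11 log units; within the scatter)) stays within the scatter. Nothing measured here gives a reason for these steps.

All four compounds carry a six-membered aromatic ring of carbon only on this nitrogen, which leaves open whether a ring bearing an amine or a carboxylic acid, or a longer chain in place of ethyl, would bring the number lower. From the compounds shown here alone, whether changes elsewhere on the shared core would move it further also remains open.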